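Swapping Methoxy for Iodo on a Weakly Cytotoxic Core

The source may hold more compounds than are shown below. What is called first, only, known or untested is meant among the compounds shown, and "the series" means these compounds.

Compound 1 (`COc1ccccc1-n1cc(COc2c(/C=C\C(=O)O)ccc(OC)c2CC=C(C)C)nn1`) was tested in a functional assay on A549 cells (Homo sapiens) for cytotoxicity, read by MTT assay, with a stated time of 24 h (on this read-out lower numbers stand for stronger inhibition and higher numbers for weaker inhibition), where compound 1 gives 43000 nM, a weak effect on the viability of the cells. Among the compounds gathered here, compound 1 is the only one with a number attached to it. Compound 2 (`COc1ccc(/C=C\C(=O)O)c(OCc2cn(-c3ccccc3C(=O)N3CCC(O)C3)nn2)c1CC=C(C)C`), which carries a different group on the same shared core, is recorded in this assay as "not determined" (no result reported), so nothing can be said of how it behaves. Compound 3 (`COc1ccc(/C=C\C(=O)O)c(OCc2cn(-c3ccccc3I)nn2)c1CC=C(C)C`) differs from compound 1 in one place: iodo in place of methoxy on an aromatic carbon. The rest of the shared core is unchanged between them. Within the data shown here, no pair of measured compounds shows what this kind of swap does in this assay, so any expectation rests on compound 1 alone and on the change itself. With a single anchor, the expected step of a 1.4-fold lower number from compound 1 to compound 3 (0.16 log units; within the scatter) is small and may stay within the scatter of repeated measurements. Compound 3 is therefore expected to land near 30000 nM in this assay, within an estimated range from 8000 nM to 100000 nM.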

Compound 3, half-maximal inhibitory concentration: 2200 nM
Estimate against measurement, compound 3: 14-fold (1.13 log units) above; the whole stated range lies above it.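

Swapping the 2-methoxyphenyl group for 2-iodophenyl gives, in this assay, a 20-fold lower number from compound 1 to compound 3 (1.29 log units; beyond the scatter), a large step beyond the scatter of repeated measurements. This shows what compound 1 alone could not: this aromatic position is sensitive, and changing this single group, with the rest of the shared core unchanged, is enough to alter the read-out clearly. No measured finding here explains the step, so the result records what happens without showing why.

On these data alone, how a chloro group, a bromo group or an amine at this same position would compare remains open, so it cannot be said whether the step depends on iodo in particular or on the loss of methoxy. Any step involving compound 2 cannot be read, as it has no reported result, and this single pair cannot show whether the same swap would have a similar effect on a different core or on other cells.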